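The source may hold more compounds than are shown below. What is called first, only, known or untested is meant among the compounds shown, and "the series" means these compounds.

Two compounds sharing one core have been examined in an ADME assay on HEL cells (Homo sapiens) for cytotoxicity, with a stated time of 3 days; a lower number here means that less compound is tolerated, a higher number that more compound is tolerated. Compound 1 `CCC1(Cc2ccccc2)OS(=O)(=O)C=C1OCC(=O)OC` returns only a limit of the assay in this assay, namely > 200000 nM, so no exact number is known for it. Compound 2 `CC(C)C1(Cc2ccccc2)OS(=O)(=O)C=C1OCc1ccccc1` gives 200000 nM in this assay. Compound 2 therefore holds the only true number shown, since the other entry sits at the limit of > 200000 nM in this assay, at which 1 of the 2 values shown sits. Compound 3 `O=S1(=O)C=C(OCc2ccccc2)C(Cc2ccccc2)(Cc2ccccc2)O1` has not yet been measured. It differs from compound 2 in a single place, benzyl in place of isopropyl on a saturated ring carbon. Among the measured compounds shown here, no measured step between two compounds is available, so the size of such a change cannot be read from anything measured. In this assay the step of a 1.3-fold lower number from compound 2 to compound 3 (0.12 log units; within the scatter) is expected to stay within the usual scatter. Compound 3 is estimated to give about 150000 nM in this assay, within a range from 50000 nM to 300000 nM.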

Compound 3, half-maximal cytotoxic concentration: 200000 nM
Estimate against measurement, compound 3: 1.3-fold (0.12 log units) below; the measured number falls inside the stated range.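

In this assay, putting benzyl in place of isopropyl on the saturated ring carbon next to the ring oxygen gives no change at the digits printed from compound 2 to compound 3 (within the scatter). Among the compounds shown here, this is the first measured step at this position, and it shows that a larger group of 7 heavy atoms, carrying its own six-membered aromatic ring, can replace one of 3 heavy atoms with no change beyond the usual scatter in this one pair. The value of compound 1 remains a limit of the assay and not a number: the limit of > 200000 nM in this assay, at which 1 of the 3 values shown sits.

The compounds shown leave open whether a group of a different kind at this carbon, such as an amine or a carboxylic acid, would also leave the number unchanged. One step also cannot show whether the same swap would give the same result with a different group on the ring oxygen-bearing side of the molecule.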